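Amide-nitrogen linker extension from compound 2 to compound 4

The compounds below may be only part of what the source reports. "The series", "measured", "known", "first", "only" and "open" are said of these compounds alone.

Three measured compounds carry the same core: compound 1 `Cc1cc(C)cc(S(=O)(=O)c2c(C(=O)NCc3ccccc3N)[nH]c3ccc(Cl)cc23)c1`, compound 2 `Cc1cc(C)cc(S(=O)(=O)c2c(C(=O)NC(C)c3ccccc3O)[nH]c3ccc(Cl)cc23)c1` and compound 3 `Cc1cc(C)cc(S(=O)(=O)c2c(C(=O)NCc3cccc(O)c3)[nH]c3ccccc23)c1`. Compound 4 `Cc1cc(C)cc(S(=O)(=O)c2c(C(=O)NCC(=O)NCc3ccccc3O)[nH]c3ccc(Cl)cc23)c1` awaits measurement.

In an ADME assay on MT4 cells (Homo sapiens) for cytotoxicity, read by MTT assay (on this read-out higher numbers stand for lower toxicity in this test and lower numbers for higher toxicity in this test), compound 1 gives 46200 nM. In this assay, going by the values given here, compound 2 gives 21800 nM, the lowest of the two numbers; the only measured step, a 2.1-fold lower number from compound 1 to compound 2 (0.33 log units; beyond the scatter), separates it from its nearest neighbour. For compound 3 this assay reports a limit only, > 5190 nM; this is the limit of > 5190 nM in this assay, at which 1 of the 3 values shown sits.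

Compound 4 differs from compound 2 by a group of 12 heavy atoms (9 carbon, 1 nitrogen, 2 oxygen; one six-membered aromatic ring of carbon only) in place of a group of 9 heavy atoms (8 carbon, 1 oxygen; one six-membered aromatic ring of carbon only), on an amide-type nitrogen, the entering group bringing one double bond outside aromatic rings and two hydrogen-bond donors with two acceptors where the leaving group had one of each.

Among the compounds with values here, only the step from compound 1 to compound 2 bears on this change, as an exchange on the same amide-type nitrogen, and it was modest. The present change is larger in atom count but of the same kind, so in this assay compound 4 is expected to move at most modestly, most likely toward a higher number, and possibly to stay within the scatter; the expected step is a 1.4-fold higher number from compound 2 to compound 4 (0.14 log units; within the scatter). The estimate for compound 4 is 30000 nM, within 12000 nM to 80000 nM.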

Compound 4, half-maximal cytotoxic concentration: > 47300 nM
Compound 4: only a limit was reported; the forecaster's own chance of this, stated with the estimate: 25%; at least 1.5-fold (0.19 log units) between middle value and limit.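

In this assay compound 4 gives only a limit and not a number: the limit of > 47300 nM in this assay, at which 1 of the 4 values shown sits.

Replacing the group of 9 heavy atoms on the amide-type nitrogen with the group of 12 heavy atoms gives an at least 2.1-fold higher number from compound 2 to compound 4 (0.33 log units; beyond the scatter), so this position can take the larger group carrying the (2-hydroxybenzyl)carbamoyl without any move toward higher toxicity in this test, whereas the earlier exchange here ran the other way, with a 2.1-fold lower number from compound 1 to compound 2 (0.33 log units; beyond the scatter). As far as these compounds go, the comparison with the other neighbour gives an at least 1.0-fold higher number from compound 1 to compound 4 (0.01 log units; that floor lies within the scatter), so the series supports no order between these two compounds, and the true size of either step remains unknown while only a floor is available.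

The compounds shown leave open how far the real half-maximal cytotoxic concentration of compound 4 lies beyond its limit, and whether the change in the read-out follows the added carbonyl-bearing chain or the size of the group as a whole. They also leave open how the same position behaves with a carboxylic acid, a basic amine or a still longer chain on the saturated chain carbon bound to the amide-type nitrogen.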